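This account rests on a few compounds, and the source may have more. Where it says the series, first, only, none or still open, it means among the compounds named here.

Compound 1 `Cc1cccc(NC(=O)CN2CCC(c3ccccc3C#N)CC2)c1` is an amide whose core carries a 2-cyanophenyl group on a saturated ring carbon. In a functional assay on HEK293 cells for agonist activity at D(4) dopamine receptor (Homo sapiens), read by FLIPR (on this read-out lower numbers stand for smaller maximal responses and higher numbers for larger maximal responses), compound 1 gives 71%, the higher of the two values known here. Compound 2 `CSc1cccc(NC(=O)CN2CCC(c3cccc[n+]3[O-])CC2)c1`, which differs in more than one place, gives in this assay 56%, a response beyond the scatter below that of compound 1, so compound 1 stands on top of the two measured numbers.

Compound 3 `Cc1cccc(NC(=O)CN2CCC(c3cccc(O)c3)CC2)c1` has not been measured. Its difference from compound 1 is 3-hydroxyphenyl in place of 2-cyanophenyl on a saturated ring carbon. Among the measured compounds shown here, no step between measured compounds resembles this change, so the direction can only be guessed from the two values in hand.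

Compound 3 is expected to reach a somewhat smaller maximal response, an estimated step of a number 11 percentage points lower from compound 1 to compound 3 (beyond the scatter), probably not far beyond the scatter. The estimate for compound 3 in this assay is 60%, with a range from 35% to 85%.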

Compound 3, largest response reached (reported as efficacy), in percent of the reference or control that the assay uses: 66%
Compound 3: the middle estimate sits 6 percentage points below what was measured; the measured number falls inside the stated range.
By their numbers in this assay, from the lowest: compounds 2, 3 and 1 (each within the scatter of the next, the first and the last beyond it).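

In this assay, putting 3-hydroxyphenyl in place of 2-cyanophenyl on the saturated ring carbon gives a number 5 percentage points lower from compound 1 to compound 3 (within the scatter), the first step read at this position. In this pair, the nitrile is therefore not needed for a maximal response that stays within the scatter of that of compound 1, and a group with a hydrogen-bond donor is accepted at the same place. No measurement of any property of these groups is available to account for this result.

The compounds shown leave open whether the hydroxyl group or its place on the phenyl ring matters, as neither 2-hydroxyphenyl nor unsubstituted phenyl appears among them. They also do not tell how an amine or a carboxylic acid on this phenyl ring would change the maximal response.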